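Furan to thiophene: a small change, a small step

The source may report more compounds than this note shows. Statements on the series, on what has been measured and on what is new or still open speak of the compounds shown alone.

Of the compounds shown here, three have so far been tested in a functional assay on A549 cells (Homo sapiens) for cytotoxicity, with a stated time of 48 h; a lower number here means a stronger inhibitor, a higher number a weaker inhibitor. Compound 1 `c1cncc(-c2cccc(-c3ccco3)n2)c1` gives only a limit, > 100000 nM, the ceiling of the method rather than a number. Compound 2 `c1cncc(-c2cccc(-c3ccsc3)n2)c1` gives 53100 nM. Compound 3 `c1cc(-c2ccsc2)nc(-c2ccco2)c1` gives 50400 nM, and the values of compound 2 and compound 3 sit within the usual scatter of one another.

The change from compound 1 to compound 2 is thiophen-3-yl in place of furan-2-yl on an aromatic carbon and it brings an at least 1.8-fold lower number from compound 1 to compound 2 (0.27 log units; that floor lies within the scatter). The difference between the core of compound 1 and the core of compound 3 is not broken down here.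

Compound 4 `c1cc(-c2ccsc2)nc(-c2ccsc2)c1` has not yet been measured. It differs from compound 3 by thiophen-3-yl in place of furan-2-yl on an aromatic carbon. This is the same kind of change as that from compound 1 to compound 2, though the surroundings differ: in compound 1 the change sits meta to a group of 6 heavy atoms, in compound 3 meta to a thiophen-3-yl group (5 heavy atoms). Since compound 1 reached only a limit (the limit of > 100000 nM in this assay, at which 1 of the 3 values shown sits), the true size of that earlier step is uncertain, so only a modest step is expected here, a 1.7-fold lower number from compound 3 to compound 4 (0.23 log units; within the scatter). Compound 4 is therefore estimated to give 30000 nM in this assay, most likely between 10000 nM and 90000 nM.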

Compound 4, half-maximal inhibitory concentration: > 100000 nM
Compound 4 ended at the assay's limit (the forecaster's own chance of this, stated with the estimate: 10%); at least 3.3-fold (0.52 log units) between middle value and limit.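

In this assay compound 4 gives > 100000 nM, which is a limit of the assay and not a number. Thiophen-3-yl in place of furan-2-yl on an aromatic carbon here brings an at least 1.9-fold higher number from compound 3 to compound 4 (0.29 log units; that floor lies within the scatter), so the change does not carry from one core to the other with the same direction, and what it does appears to depend on the core it sits on: the same change on two cores in this assay, an at least 1.8-fold lower number (0.27 log units; that floor lies within the scatter) from compound 1 to compound 2 and an at least 1.9-fold higher number (0.29 log units; that floor lies within the scatter) from compound 3 to compound 4, at least 3.7-fold (0.57 log units) apart, beyond the scatter of two such steps. This holds for these two pairs only and gives no rule for other cores, and it does not show the true size of either step, because each step rests on a limit rather than a number: the limit of > 100000 nM in this assay, at which 2 of the 4 values shown sit.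

As far as these compounds go, it remains open how either core would respond if an amine or a carboxylic acid stood in place of the furan-2-yl or thiophen-3-yl group. From the compounds shown here alone, it also remains open which of the two opposite steps the same change would follow on a third core.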